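A few compounds are considered here, and "the series" means these few. Any claim that something is new, unique, unknown or untested is made for them only; others in the source may bear on it.

Measured so far in a functional assay on trachea (Cavia porcellus); on this read-out higher numbers stand for weaker inhibition and lower numbers for stronger inhibition: compound 1 `CO[C@@]12CCN(C)C[C@H]1[C@H](c1ccccc1)C(C#N)=C(N)O2`, 19800 nM; compound 2 `CCCN1CC[C@@]2(OC)OC(N)=C(C#N)[C@@H](c3ccccc3)[C@@H]2C1`, 20700 nM.

Compound 1 and compound 2 sit side by side, since the step of a 1.0-fold higher number from compound 1 to compound 2 (0.02 log units; within the scatter) lies within the scatter. Compound 3 `CO[C@@]12CCN(C)C[C@H]1[C@H](c1ccc(F)cc1)C(C#N)=C(N)O2` differs from compound 1 by fluoro in place of hydrogen on an aromatic carbon. Among the compounds with values here, the only measured step, from compound 1 to compound 2, touched the chain on the ring nitrogen and not the aromatic ring, so it gives no direct guide to this change; it moved nothing beyond the scatter. Within the data shown here, with no step bearing on it, the expected step of a 1.0-fold higher number from compound 1 to compound 3 (0.00 log units; within the scatter) is none beyond the scatter. Compound 3 is therefore estimated to give 20000 nM in this assay, between 8000 nM and 50000 nM.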

Compound 3, half-maximal inhibitory concentration: 19400 nM
Beside the measured number, compound 3's estimate is 1.0-fold (0.01 log units) above it; the range from low to high includes it.
By their numbers in this assay, from the lowest: compounds 3, 1 and 2 (each within the scatter of the next).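

Within the data shown here, the step of a 1.0-fold lower number from compound 1 to compound 3 (0.01 log units; within the scatter) is the first measured change on the aromatic ring of the shared core in this assay. It shows that swapping phenyl for 4-fluorophenyl, with fluoro para to a large group, leaves the number in place, so this single small atom can be added here without a measurable shift. Nothing measured here offers an explanation for this flat result. From the compounds shown here alone, whether a bulkier group at the same place, such as methoxy or trifluoromethyl, would shift the number remains open. So does the effect of an amine on this ring.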